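From bromo to methoxy in a weakly active set

The source may report more compounds than this note shows. Statements on the series, on what has been measured and on what is new or still open speak of the compounds shown alone.

Compound 1 `O=C(/C=C/c1ccccn1)c1nc2ccccc2s1`: > 100000 nM
Compound 2 `O=C(/C=C/c1cccc(Cl)c1)c1nc2ccccc2s1`: > 100000 nM
Compound 3 `O=C(/C=C/c1ccccc1Br)c1nc2ccccc2[nH]1`: 29200 nM

All three compounds were tested in a functional assay on HepG2 cells (Homo sapiens) for antiproliferative activity, read by MTT assay, with a stated time of 48 h; on this read-out higher numbers stand for weaker inhibition and lower numbers for stronger inhibition. Compound 1 reads > 100000 nM, which is a limit of the assay and not a number. Compound 2 reads > 100000 nM, also a limit. Going by the values given here, compound 3 gives 29200 nM, the only true number in the set. The rest of the picture is the limit of > 100000 nM in this assay, at which 2 of the 3 values shown sit.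

Compound 4 `COc1ccccc1/C=C/C(=O)c1nc2ccccc2[nH]1` keeps the core of compound 3 and has methoxy in place of bromo on an aromatic carbon, ortho to a large group: methoxy in place of bromo on an aromatic carbon. Among the compounds with values here, no measured pair shows this exchange, so the expectation has no direct precedent. In this assay a small step towards weaker inhibition is expected, and it may stay within the usual scatter. The estimated change is a 1.4-fold higher number from compound 3 to compound 4 (0.14 log units; within the scatter). For compound 4 the expected value is 40000 nM, with an estimated range from 13000 nM to 100000 nM.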

Compound 4, half-maximal inhibitory concentration: 7990 nM
Estimate against measurement, compound 4: 5.0-fold (0.70 log units) above, and the stated range ends above it.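

The position ortho to a large group, where compound 3 carries bromo, responds to this exchange: in this assay, methoxy in place of bromo gives a 3.7-fold lower number from compound 3 to compound 4 (0.56 log units; beyond the scatter). Going by these compounds alone, on this core, therefore, bromo is not required for a measurable value, and the change at this position moves the read-out towards stronger inhibition, a comparison that the earlier compounds could not offer. Nothing measured here accounts for the size or direction of this step.

Going by these compounds, with one exchange at one position, it remains open whether the gain is particular to methoxy or would also appear with ethoxy, hydroxy or an amine at the same place. On these data alone, it is equally open whether methoxy would give a true number on the core of compound 2.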